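The source may hold more compounds than are shown below. What is called first, only, known or untested is meant among the compounds shown, and "the series" means these compounds.

Measured so far:
compound 1 `COc1cc(C)cc(-c2c(-c3ccnc(-c4ccc(N(C)C)cc4)c3)cnn2CC#N)c1`: 13%
compound 2 `COc1cc(C)cc(-c2nn(CC#N)cc2-c2ccnc(-c3ccc(N(C)C)cc3)c2)c1`: 17%

In a functional assay on PC-3 cells (Homo sapiens) for cytotoxicity, read by sulforhodamine B assay, with a stated time of 48 h, tested at 1 uM (a higher number here means a weaker effect of the compound at the concentration tested, a lower number a stronger effect), compound 1 gives 13%. In this assay compound 2 gives 17%; the two numbers lie within the scatter of each other, so compound 2 is not set apart from compound 1 on this read-out, and both sit at the strong end of what the percentage can show. Going by the values given here, no step between measured compounds that differ in a single place is available, so the numbers themselves say nothing about what one change does.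

Compound 3 `Cc1cc(O)cc(-c2nn(CC#N)cc2-c2ccnc(-c3ccc(N(C)C)cc3)c2)c1` is the next member. It differs from compound 2 by hydrogen in place of methyl on an oxygen on an aromatic ring. Among the compounds with values here, with no comparable step recorded, the expectation rests on the change alone: a modest move toward a weaker effect, of a size that may well stay within the scatter, is expected, as a number 8 percentage points higher from compound 2 to compound 3 (within the scatter). Compound 3 is accordingly estimated at 25% in this assay, within a range from 8% to 60%.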

Compound 3, a percentage reported as activity, at one concentration (the size of the read-out at that concentration, not a potency): 18%
Compound 3: the middle estimate sits 7 percentage points above what was measured; low and high end bracket the measured number.
By their numbers in this assay, from the lowest: compounds 1, 2 and 3 (each within the scatter of the next).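

In this assay, the change from methoxy to hydroxy gives a number 1 percentage points higher from compound 2 to compound 3 (within the scatter), the first single-place step available in this series. Hydrogen in place of methyl on an oxygen on an aromatic ring therefore does not set compound 3 apart from compound 2 on this read-out. At this one concentration, the methyl on that oxygen can be removed without a change beyond the scatter. No supporting measurement bears on why this is so.

The compounds shown leave open whether an ethoxy group or a longer chain on the same oxygen, or an amine in place of the hydroxy group, would also stay within the scatter of compound 2. A single-concentration read-out also leaves open whether compound 2 and compound 3 differ in potency.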